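Expected tolerance of compound 3

This account rests on a few compounds, and the source may have more. Where it says the series, first, only, none or still open, it means among the compounds named here.

Measured in an ADME assay on MT4 cells (Homo sapiens) for cytotoxicity, read by MTT assay; a higher number here means that more compound is tolerated, a lower number that less compound is tolerated:
Compound 1 `Cc1cc(C)cc(S(=O)(=O)c2c(C(=O)NCC(=O)NC(C)c3ccccc3)[nH]c3ccc(Cl)cc23)c1`: 29400 nM
Compound 2 `Cc1cc(C)cc(S(=O)(=O)c2c(C(=O)NCc3cccc(N)c3)[nH]c3ccc(Cl)cc23)c1`: > 53400 nM, a limit

Compound 2 stands at a limit of this assay, > 53400 nM, and has no exact number. Compound 3 `Cc1cc(C)cc(S(=O)(=O)c2c(C(=O)NCC(=O)NCc3ccco3)[nH]c3ccc(Cl)cc23)c1` is the next structure, and the change is ((furan-2-yl)methyl)carbamoyl in place of 3-aminophenyl on a saturated chain carbon bound to an amide-type nitrogen. Among the measured compounds shown here, the only measured step that bears on it is an at least 1.8-fold higher number from compound 1 to compound 2 (0.25 log units; that floor lies within the scatter). Compound 3 again carries a carbamoyl group on that chain carbon, as does compound 1 at 29400 nM. A small move to a lower number is therefore expected, perhaps none beyond the scatter. The expected step is an at least 1.6-fold lower number from compound 2 to compound 3 (0.20 log units; that floor lies within the scatter). For compound 3 the estimated value is 33000 nM, with an expected range of 15000 nM to 60000 nM.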

Compound 3, half-maximal cytotoxic concentration: > 50000 nM
Compound 3: a limit, no number; the forecaster's own chance of this, stated with the estimate: 30%; at least 1.5-fold (0.18 log units) between middle value and limit.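

In this assay compound 3 gives > 50000 nM, which is a limit and not a number. Replacing 1-phenylethyl with (furan-2-yl)methyl on the amide-type nitrogen gives an at least 1.7-fold higher number from compound 1 to compound 3 (0.23 log units; that floor lies within the scatter), so a carbamoyl group on the saturated chain carbon does not by itself tie a compound to the measured value of compound 1. The step from compound 2 to compound 3 cannot be read, as both values are limits.

On these data alone, how far compound 2 and compound 3 lie past their limits stays open. Also open, as far as these compounds go, is whether a carboxylic acid or a longer chain on that amide-type nitrogen would give a measurable number.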